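Oxadiazole to Thiadiazole: Compound 2 to Compound 3

The compounds below may be only part of what the source reports. "The series", "measured", "known", "first", "only" and "open" are said of these compounds alone.

Measured so far:
Compound 1, `O=c1cc(CSc2nc3ccccc3s2)oc2ccc(Cl)cc12`: > 25000 nM in a functional assay on HeLa cells (Homo sapiens) for cytotoxicity, read by MTT assay, with a stated time of 72 h (on this read-out lower numbers stand for stronger inhibition and higher numbers for weaker inhibition), a limit of that assay rather than a number.
Compound 2, `Cc1nnc(SCc2coc3ccc(Cl)cc3c2=O)o1`: 3200 nM in this assay.

Going by the values given here, compound 2 holds the only number given in this assay; the other entry is a limit. Compound 1 sits at the limit of > 25000 nM in this assay, at which 1 of the 2 values shown sits, and that sentence says all that its value can say.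

Compound 3, `Cc1nnc(SCc2coc3ccc(Cl)cc3c2=O)s1`, has not yet been measured. It differs from compound 2 in one place: 5-methyl-1,3,4-thiadiazol-2-yl in place of 5-methyl-1,3,4-oxadiazol-2-yl on a sulfur.

Among the compounds with values here, no step between two measured compounds is available, so the size of this change must be guessed. The exchange keeps the ring size, the count of hetero atoms and the acceptor count, so the expected step from compound 2 to compound 3 is a 1.5-fold lower number from compound 2 to compound 3 (0.16 log units; within the scatter), a small shift toward stronger inhibition that need not exceed the scatter. Compound 3 is therefore expected at 2200 nM, between 700 nM and 7000 nM.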

Compound 3, half-maximal inhibitory concentration: 9700 nM
Compound 3: the middle estimate sits 4.4-fold (0.64 log units) below what was measured; the whole stated range lies below it.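

In this assay, going by these compounds alone, 5-methyl-1,3,4-thiadiazol-2-yl in place of 5-methyl-1,3,4-oxadiazol-2-yl on a sulfur gives a 3.0-fold higher number from compound 2 to compound 3 (0.48 log units; beyond the scatter), the first step that can be read at this place. The place therefore responds to the exchange of one ring oxygen for one ring sulfur, even though the heavy-atom count, the hydrogen-bond donors and acceptors and the net charge stay the same. Nothing measured in the compounds shown accounts for this step.

The compounds shown leave open how the same place would respond to a ring carrying an amine or a carboxylic acid instead of the methyl group. Within the data shown here, they also leave open whether this step would hold on a core other than the one shared by compound 2 and compound 3.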